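A sulfanyl group replaces a sulfonyl group on compound 1

The compounds below may be only part of what the source reports. "The series", "measured", "known", "first", "only" and "open" are said of these compounds alone.

compound 1 `Cc1ccc(CS(=O)(=O)/C(=C/c2ccccc2OCc2ccccc2)C(=O)c2ccc(Cl)cc2)cc1` - 1000 nM
compound 2 `Cc1ccsc1/C=C(\C(=O)c1ccc(Cl)cc1)S(=O)(=O)Cc1ccc(F)cc1` - 10000 nM
compound 3 `O=C(/C(=C\c1ccc(OC(F)(F)F)cc1)S(=O)(=O)c1ccc(Br)cc1)c1ccc(Br)cc1` - 25000 nM

In a functional assay on DU-145 cells (Homo sapiens) for inhibition, read by trypan blue exclusion, with a stated time of 96 h (on this read-out higher numbers stand for weaker inhibition of growth and lower numbers for stronger inhibition of growth), compound 1 reads lowest of the three, and its gaps to compound 2 and compound 3 both lie beyond the scatter. Compound 4 `COc1ccc(S/C(=C/c2ccccc2OCc2ccccc2)C(=O)c2ccc(Cl)cc2)cc1` remains unmeasured. It carries (4-methoxyphenyl)sulfanyl in place of (4-methylbenzyl)sulfonyl on a double-bonded chain carbon bound to a carbonyl carbon and a double-bonded chain carbon. Within the data shown here, no measured pair isolates this change, so the expectation is loose. Compound 1 at 1000 nM already sits at the low end of the series, so a moderate move to a higher number, meaning weaker inhibition, is expected. The expected step is a 4.0-fold higher number from compound 1 to compound 4 (0.60 log units; beyond the scatter). For compound 4 the estimate is 4000 nM, within an expected range of 1000 nM to 20000 nM.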

Compound 4, concentration for 50% growth inhibition: 1000 nM
Compound 4: the middle estimate sits 4.0-fold (0.60 log units) above what was measured; the measured number falls inside the stated range.
By their numbers in this assay, from the lowest: compounds 1 and 4 (each within the scatter of the next); then compound 2; then compound 3.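

Among these compounds, exchanging (4-methylbenzyl)sulfonyl for (4-methoxyphenyl)sulfanyl on a double-bonded chain carbon bound to a carbonyl carbon and a double-bonded chain carbon gives, in this assay, no change at the digits printed from compound 1 to compound 4 (within the scatter) and so provides the first single-place comparison in this set. At this position, the sulfonyl group is therefore not required for the low number of compound 1. Nothing shown explains why the two compounds read alike.

The step alters the sulfur group, the benzyl link and the ring's methyl or methoxy group together, leaving open which of these matters. It also leaves open how an amine or a carboxylic acid on that ring would read.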